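A few compounds are considered here, and "the series" means these few. Any claim that something is new, unique, unknown or untested is made for them only; others in the source may bear on it.

Working notes on the adenosine-type series in a functional assay on HL-60 cells (Homo sapiens) for antiproliferative activity, with a stated time of 72 h; on this read-out higher numbers stand for weaker inhibition and lower numbers for stronger inhibition. For the measured compounds named here, compound 2 `OC[C@H]1O[C@@H](n2cnc3c(NCc4ccc(Cl)cc4Cl)ncnc32)[C@H](O)[C@@H]1O` gives 96300 nM, the highest of the two numbers so far; its nearest neighbour is compound 1 `OC[C@H]1O[C@@H](n2cnc3c(NCc4ccccc4Br)ncnc32)[C@H](O)[C@@H]1O`, which in this assay gives 6600 nM. Going by the values given here, the one step measured, a 15-fold higher number from compound 1 to compound 2 (1.16 log units; beyond the scatter), shows that the aryl group on a saturated chain carbon bound to a nitrogen on an aromatic ring can shift the read-out by a large amount. Compound 3 `Cc1cccc(CNc2ncnc3c2ncn3[C@@H]2O[C@H](CO)[C@@H](O)[C@H]2O)c1O` is now to be measured; it differs from compound 2 by 2-hydroxy-3-methylphenyl in place of 2,4-dichlorophenyl on a saturated chain carbon bound to a nitrogen on an aromatic ring. Among the compounds with values here, no measured step involves a hydroxy or methyl substituent on this ring, so the direction of the change is uncertain; the only precedent shows that a change of aryl substitution here is capable of a large effect. Compound 3 is therefore expected to move by a 4.8-fold lower number from compound 2 to compound 3 (0.68 log units; beyond the scatter), with the estimate for compound 3 placed at 20000 nM within the range 3000 nM to 150000 nM.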

Compound 3, half-maximal inhibitory concentration: 15000 nM
Beside the measured number, compound 3's estimate is 1.3-fold (0.12 log units) above it; the measured number falls inside the stated range.
By their numbers in this assay, from the lowest: compound 1; then compound 3; then compound 2.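

In this assay, a 6.4-fold lower number from compound 2 to compound 3 (0.81 log units; beyond the scatter) shows that an aryl group with a hydroxy and a methyl substituent can recover much of the number lost with 2,4-dichlorophenyl, so the large earlier step is not a one-way effect of changing the aryl group at this position. Yet a 2.3-fold higher number from compound 1 to compound 3 (0.36 log units; beyond the scatter) keeps 2-hydroxy-3-methylphenyl on the weaker side of 2-bromophenyl, which gives a three-member order at this one place, with compound 1 lowest and compound 2 highest. Nothing available bears on why these aryl changes shift the read-out.

On these data alone, the hydroxy and methyl groups enter together, so their separate contributions remain open. Also open, as far as these compounds go, is how this position responds to a phenyl ring carrying an amine or a carboxylic acid, or to a longer chain in place of the benzyl link.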